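Flipping one ring stereocentre on the cyclopropyl amide

The source may report more compounds than this note shows. Statements on the series, on what has been measured and on what is new or still open speak of the compounds shown alone.

Compound 2 `C[C@@H]1C[C@@H]1C(=O)N1CC2CC(C1)N2` stands highest of the two numbers in an assay on CHO cells for agonist activity at Neuronal acetylcholine receptor; alpha3/alpha6/beta2/beta3 (Homo sapiens), read by FLIPR and calcium flux (on this read-out higher numbers stand for an effect only at larger amounts of compound and lower numbers for an effect already at smaller amounts), where compound 2 gives 920 nM. Its nearest neighbour, compound 1 `CCC(=O)N1CC2CC(C1)N2`, gives 180 nM in this assay, and the step of a 5.1-fold higher number from compound 1 to compound 2 (0.71 log units; beyond the scatter) is the only measured one. Compound 3 `C[C@H]1C[C@@H]1C(=O)N1CC2CC(C1)N2` differs from compound 2 thus: the two compounds have the same atoms and bonds; at least one stereo element is drawn with a configuration in one of them and without one in the other: 1 of 4 stereo elements differ; a stereocentre at a saturated ring carbon is drawn R in compound 2 and S in compound 3. Among the measured compounds shown here, no measured step concerns a change of configuration alone, so compound 1 and compound 2 give no guide to its size or direction. Compound 3 is therefore expected close to compound 2, with a step of a 1.0-fold lower number from compound 2 to compound 3 (0.01 log units; within the scatter) and an estimate of 900 nM, within 200 nM to 4000 nM.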

Compound 3, half-maximal effective concentration: 3800 nM
Compound 3: middle estimate off by 4.2-fold (0.63 log units), on the low side; measured number inside the range.
By their numbers in this assay, from the lowest: compound 1; then compound 2; then compound 3.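

With atoms and bonds unchanged, configuration alone moves the number at this ring carbon in this assay: the change from R to S gives a 4.1-fold higher number from compound 2 to compound 3 (0.62 log units; beyond the scatter) in its own right. With the S centre, 2-methylcyclopropyl in place of ethyl gives a 21-fold higher number from compound 1 to compound 3 (1.32 log units; beyond the scatter) and so a larger step than the R centre showed. One qualification attaches to this comparison: the fact that one of compounds 2 and 3 is drawn with a defined configuration and the other without, at the place where they differ.

As far as these compounds go, how an unsubstituted cyclopropyl or a longer chain such as propyl would read on the same carbonyl carbon stays open, as does the effect of changing the other ring stereocentre.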